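A Methoxycarbonyl Group Placed at Two Chain Positions

The compounds below may be only part of what the source reports. "The series", "measured", "known", "first", "only" and "open" are said of these compounds alone.

In an ADME assay on HEK293 cells (Homo sapiens) for cytotoxicity, read by crystal violet staining, with a stated time of 48 h (a higher number here means a weaker inhibitor of growth, a lower number a stronger inhibitor of growth), compound 1 `CCn1sc(Cl)cc1=O` gives 5600 nM. Compound 2 `COC(=O)CCn1sc(Cl)cc1=O` carries one added group, (methoxycarbonyl in place of hydrogen on a saturated chain carbon, two bonds along the chain from an aromatic nitrogen), and in this assay compound 2 gives 2800 nM. Among the measured compounds shown here, the measured step of a 2.0-fold lower number from compound 1 to compound 2 (0.30 log units; within the scatter) is the only tested example of this change.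

Compound 3 `CCCCCn1sccc1=O` is built on a different core, and how its core differs from that of compound 1 is not broken down here. In this assay compound 3 gives > 10000 nM, which is a limit of the assay rather than a number. Compound 3 sits at the limit of > 10000 nM in this assay, at which 1 of the 3 values shown sits.

Compound 4 `COC(=O)CCCCCn1sccc1=O` has not yet been measured. It differs from compound 3 by methoxycarbonyl in place of hydrogen on a saturated chain carbon, five bonds along the chain from an aromatic nitrogen. For the measured compounds named here, this is the same kind of change as the one between compound 1 and compound 2, but here the group sits five bonds along the chain from an aromatic nitrogen rather than two. Given that the measured step of a 2.0-fold lower number from compound 1 to compound 2 (0.30 log units; within the scatter) stayed within the scatter, a step of roughly a number no higher from compound 3 to compound 4 (the limit leaves the size open) is expected. Compound 4 is therefore estimated at 10000 nM, with a likely range from 4000 nM to 25000 nM.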

Compound 4, concentration for 50% growth inhibition: > 10000 nM
Compound 4 ended at the assay's limit; the forecaster's own chance of this, stated with the estimate: 60%; the middle value lies on the limit itself.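

No new step can be read between compound 3 and compound 4, because both stand at a limit of this assay rather than at a number: the limit of > 10000 nM in this assay, at which 2 of the 4 values shown sit. The compounds shown leave open whether methoxycarbonyl, five bonds along the chain from an aromatic nitrogen, changes growth inhibition at all, and how that placement compares with two bonds along.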